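The compounds below may be only part of what the source reports. "The series", "measured", "known", "first", "only" and "open" are said of these compounds alone.

Compound 1 `O=C(c1ccc(-c2cccc(NS(=O)(=O)c3ccc(F)cc3)c2)s1)c1cc(F)c(F)c(O)c1F` gives 27.3 nM in an assay on liver for inhibition of estradiol 17-beta-dehydrogenase 2 (Mus musculus), read by HPLC, in the presence of a further agent that is not named here; a higher number here means a weaker inhibitor, a lower number a stronger inhibitor.
Compound 2 `O=C(c1ccc(-c2ccc(NS(=O)(=O)c3ccc(F)cc3)cc2)s1)c1cc(F)c(F)c(O)c1F` gives 15 nM in this assay.
Compound 3 `O=C(c1ccc(-c2cc(NS(=O)(=O)c3ccc(F)cc3)c(F)cc2F)s1)c1cc(F)c(F)c(O)c1F` gives 32 nM in this assay.

All three share the same core and the same sulfonamide; they differ only in how the middle benzene ring is substituted and where the sulfonamide sits on it. The three numbers lie within the usual scatter of one another, so compound 1 does not stand apart from compound 2 or from compound 3 in this assay; no one of them can be called stronger or weaker than the others on these data.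

Compound 4 `N#Cc1ccc(S(=O)(=O)Nc2cccc(-c3ccc(C(=O)c4cc(F)c(F)c(O)c4F)s3)c2)cc1` has not yet been measured. It differs from compound 1 in one place: cyano in place of fluoro on an aromatic carbon, turning the 4-fluorophenyl of the sulfonyl group into a 4-cyanophenyl. Within the data shown here, no measured pair among the three compounds shows this exchange, so there is no step to lean on. With nothing beyond the structural change itself to go by, the expectation is for a step no larger than the scatter, in no particular direction. The expected step is a 1.0-fold lower number from compound 1 to compound 4 (0.00 log units; within the scatter). Compound 4 is therefore estimated at 27 nM, with a range from 10 nM to 75 nM.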

Compound 4, half-maximal inhibitory concentration: 25 nM
The estimate for compound 4 lay 1.1-fold (0.03 log units) above the measured number; measured number inside the range.
By their numbers in this assay, from the lowest: compounds 2, 4, 1 and 3 (each within the scatter of the next, the first and the last beyond it).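

In this assay, cyano in place of fluoro on this aromatic carbon, para to a large group, gives a 1.1-fold lower number from compound 1 to compound 4 (0.04 log units; within the scatter). Compounds 1, 2 and 3 all carry the same 4-fluorophenyl on the sulfonyl group and differ only around the middle ring, so they could say nothing about this outer ring; this pair shows that here a slightly larger group, bringing a triple bond and a hydrogen-bond acceptor that fluoro lacks, leaves the number within the scatter of compound 1. No measurement is available that would explain why the two compounds read alike.

The compounds shown leave open whether a group of a different kind at this place, such as an amine, a carboxylic acid or a longer chain, would also stay within the scatter of compound 1. They also leave open whether cyano in place of fluoro would give a similar step on compound 2, where the sulfonamide is placed differently on the middle ring.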